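This account rests on a few compounds, and the source may have more. Where it says the series, first, only, none or still open, it means among the compounds named here.

In an ADME assay on L929 cells (Mus musculus) for cytotoxicity, read by resazurin assay, with a stated time of 72 h (on this read-out higher numbers stand for weaker inhibition and lower numbers for stronger inhibition), compound 1 `COc1cc(C(=O)/C=C/c2ccc3c(c2)B(O)OC3)cc(OC)c1OC` gives > 10 ug/mL, which is a limit of the assay rather than a number. Compound 3 `O=C(/C=C/c1ccc2c(c1)B(O)OC2)c1cccs1` likewise gives > 10 ug/mL, again a limit. Compound 2 `O=C(/C=C/c1ccc2c(c1)B(O)OC2)c1ccc(OCc2ccccc2)cc1` in turn gives > 10 ug/mL, also a limit. Compound 2 thus stands where every value shown stands, because of the limit of > 10 ug/mL in this assay, at which 3 of the 3 values shown sit. Compound 4 `O=C(O)c1ccc(C(=O)/C=C/c2ccc3c(c2)B(O)OC3)cc1` differs from compound 2 in one place: carboxy in place of benzyloxy on an aromatic carbon. Among the measured compounds shown here, no pair of measured compounds differing in a single place has been compared here, so the size of such a change cannot be read from earlier pairs. With all three values sitting at the limit, the step expected in this assay is a step that the limit leaves unreadable from compound 2 to compound 4, nothing beyond the usual scatter. Compound 4 is therefore estimated at 15 ug/mL, with a likely range from 7 ug/mL to 40 ug/mL.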

Compound 4, half-maximal inhibitory concentration: > 10 ug/mL
Compound 4: no number, only a limit (the forecaster's own chance of this, stated with the estimate: 85%); the middle value does not contradict the limit.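

Compound 2 and compound 4 both sit at a limit rather than at a number, so no step can be read between them. The compounds shown leave open how carboxy and benzyloxy compare in this assay.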